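Rearranging an amino ester side chain on a weak antiproliferative

This account rests on a few compounds, and the source may have more. Where it says the series, first, only, none or still open, it means among the compounds named here.

Among the compounds with values here, compound 1 `COC(=O)CN(C)c1nc(Nc2cccc(OC)c2)ncc1[N+](=O)[O-]` is the only compound with a measured number in a functional assay on HepG2 cells (Homo sapiens) for antiproliferative activity, read by MTT assay, with a stated time of 48 h (on this read-out higher numbers stand for weaker inhibition and lower numbers for stronger inhibition), where compound 1 gives 73400 nM. Compound 2 `COC(=O)CN(C)c1nc(Nc2ccccc2)ncc1[N+](=O)[O-]` reaches only the limit (the limit of > 100000 nM in this assay, at which 1 of the 2 values shown sits), so in this assay compound 2 gives > 100000 nM, a limit rather than a number. The step of an at least 1.3-fold higher number from compound 1 to compound 2 (0.13 log units; that floor lies within the scatter) concerns a different place and does not bear on the change now followed. Compound 3 `CCOC(=O)CNc1nc(Nc2cccc(OC)c2)ncc1[N+](=O)[O-]` carries ((ethoxycarbonyl)methyl)amino in place of ((methoxycarbonyl)methyl)(methyl)amino on an aromatic carbon. Within the data shown here, no measured step touches this change, so nothing beyond the scatter is expected. Compound 3 is estimated at 70000 nM, between 25000 nM and 200000 nM. The expected step for compound 3 is a 1.0-fold lower number from compound 1 to compound 3 (0.02 log units; within the scatter).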

Compound 3, half-maximal inhibitory concentration: > 100000 nM
Compound 3 was reported as a limit (the forecaster's own chance of this, stated with the estimate: 35%); at least 1.4-fold (0.15 log units) between middle value and limit.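

In this assay, replacing ((methoxycarbonyl)methyl)(methyl)amino with ((ethoxycarbonyl)methyl)amino on this aromatic carbon gives an at least 1.3-fold higher number from compound 1 to compound 3 (0.13 log units; that floor lies within the scatter). This rearrangement of the same atoms therefore yields no readable gain at this position, and any loss cannot be sized, as compound 3 ends at a limit and not a number. Most of the compounds shown now sit at that limit: the limit of > 100000 nM in this assay, at which 2 of the 3 values shown sit.

On these data alone, it remains open whether the missing nitrogen methyl or the ethyl ester matters more. Also open, as far as these compounds go, is how a carboxylic acid or a longer chain would behave here.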